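This account rests on a few compounds, and the source may have more. Where it says the series, first, only, none or still open, it means among the compounds named here.

Compound 1 `COc1ccc(C2=Cc3ccc(F)cc3C(CC(C)=O)N2c2ccc(O)cc2)cc1` — in an ADME assay on TZM cells (Homo sapiens) for cytotoxicity, read by CellTiter-Glo, with a stated time of 48 h (on this read-out higher numbers stand for lower toxicity in this test and lower numbers for higher toxicity in this test), compound 1 gives 60500 nM
Compound 2 `COc1ccc(C2=Cc3ccc(F)cc3C(CC(C)=O)N2c2ccc(F)cc2)cc1` — in this assay compound 2 gives "not determined" (no result reported), so no result is reported for it

Among the compounds with values here, compound 2 therefore stands without a number of its own; the only anchor is the value of compound 1. Compound 3 `COc1ccc(C2=Cc3ccc(F)cc3C(CC(C)=O)N2c2ccc([N+](=O)[O-])cc2)cc1` differs from compound 2 by the change (nitro in place of fluoro on an aromatic carbon), that is, nitro in place of fluoro on an aromatic carbon. Within the data shown here, with no measured pair to learn from, the expected shift in this assay is small, likely no larger than the usual scatter, in either direction. Compound 3 is thus estimated at 45000 nM, within a range from 15000 nM to 100000 nM.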

Compound 3, half-maximal cytotoxic concentration: 11200 nM
Compound 3: the middle estimate sits 4.0-fold (0.60 log units) above what was measured, outside the stated range (below it).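

In this assay, the group on this aromatic carbon clearly matters: nitro in place of hydroxy brings a 5.4-fold lower number from compound 1 to compound 3 (0.73 log units; beyond the scatter), which means higher toxicity in this test. A change at this one place is therefore enough to move the result beyond the usual scatter. Nothing measured here gives a reason for the shift.

From the compounds shown here alone, compound 2 has no number, so it remains open where fluoro would fall relative to hydroxy and nitro. Going by these compounds, how an amine or a carboxylic acid on this same carbon would read also remains open.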